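Swapping the aryl group on the amine nitrogen

This account rests on a few compounds, and the source may have more. Where it says the series, first, only, none or still open, it means among the compounds named here.

Compound 2 `CCc1cccc(Nc2cc(NC(=O)Nc3cc(OC)cc(OC)c3)ncn2)c1` was tested in a functional assay on NCI-H226 cells (Homo sapiens) for inhibition, read by MTT assay, with a stated time of 48 h, tested at 10 uM (on this read-out higher numbers stand for more inhibition at the one concentration tested (going by the name of the read-out) and lower numbers for less inhibition), where compound 2 gives 36.7%, the lower of the two numbers shown, though within the scatter of compound 1 `COc1cc(NC(=O)Nc2cc(Nc3cccc(C(C)(C)C)c3)ncn2)cc(OC)c1`, which in this assay gives 40%. Within the data shown here, the only measured step, a number 3.3 percentage points lower from compound 1 to compound 2 (within the scatter), concerns a different change and lies within the scatter. Compound 3 `COc1cc(NC(=O)Nc2cc(Nc3cc(Br)ccc3OC)ncn2)cc(OC)c1` differs from compound 2 by 5-bromo-2-methoxyphenyl in place of 3-ethylphenyl on a nitrogen on an aromatic ring. Among the measured compounds shown here, with no measured step bearing directly on this change, no shift beyond the scatter is expected, the step being estimated at a number 0.3 percentage points higher from compound 2 to compound 3 (within the scatter). Compound 3 is therefore expected to give 37%, within 20% to 55%.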

Compound 3, a percentage reported as inhibition, at one concentration (the size of the read-out at that concentration, not a potency): 42.7%
Compound 3: middle estimate off by 5.7 percentage points, on the low side; the range from low to high includes it.
By their numbers in this assay, from the lowest: compounds 2, 1 and 3 (each within the scatter of the next).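

Replacing the alkylphenyl groups on the nitrogen with 5-bromo-2-methoxyphenyl gives a number 6 percentage points higher from compound 2 to compound 3 (within the scatter) against 3-ethylphenyl, and a number 2.7 percentage points higher from compound 1 to compound 3 (within the scatter) against 3-(tert-butyl)phenyl, so neither step moves the number beyond the scatter. This position therefore accepts a ring carrying bromine and methoxy as well as one carrying a simple alkyl group, with no separation among the three compounds. Nothing measured here offers an explanation for this result.

The compounds shown leave open whether the bromine or the methoxy alone would give the same number. They also leave open whether a carboxylic acid or an amine on this ring would shift it beyond the scatter.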